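Swapping the Aryl Group on a Shared Core

The source may hold more compounds than are shown below. What is called first, only, known or untested is meant among the compounds shown, and "the series" means these compounds.

Measured compounds:
compound 1 `O=C(CSc1nc(Nc2ccccc2)c2ccccc2n1)Nc1ccc(C(F)(F)F)cc1` — 11100 nM
compound 2 `C=CC(=O)Nc1cccc(NC(=O)CSc2nc(Nc3ccccc3C)c3ccccc3n2)c1` — 20400 nM

In a functional assay on MDA-MB-231 cells (Homo sapiens) for inhibition, read by MTT assay, with a stated time of 72 h (a higher number here means a weaker inhibitor, a lower number a stronger inhibitor), compound 1 gives 11100 nM and compound 2 gives 20400 nM. Compound 2 has the higher of the two numbers, but its gap to compound 1 lies within the scatter, so the two cannot be told apart. Compound 3 `C=CC(=O)Nc1cccc(NC(=O)CSc2nc(Nc3ccc(Cl)c(Cl)c3)c3ccccc3n2)c1` has not yet been measured. It differs from compound 2 by 3,4-dichlorophenyl in place of 2-methylphenyl on a nitrogen on an aromatic ring. Within the data shown here, no measured pair shows this change, so a step no larger than the scatter is expected, in either direction. Compound 3 is estimated at 15000 nM, within a range from 5000 nM to 45000 nM, which means an expected step of a 1.4-fold lower number from compound 2 to compound 3 (0.13 log units; within the scatter).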

Compound 3, half-maximal inhibitory concentration: 17700 nM
The estimate for compound 3 lay 1.2-fold (0.07 log units) below the measured number; measured number inside the range.
By their numbers in this assay, from the lowest: compounds 1, 3 and 2 (each within the scatter of the next).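

Among these compounds, putting 3,4-dichlorophenyl in place of 2-methylphenyl on this nitrogen gives in this assay a step of a 1.2-fold lower number from compound 2 to compound 3 (0.06 log units; within the scatter) and this is the first direct reading at this position. For this pair, the two chlorines in place of the methyl do not separate the compounds. No measurement shown here offers an explanation for this result.

On these data alone, whether a phenyl ring carrying an amine or a carboxylic acid on this nitrogen would give a step beyond the scatter remains open. The same is true of a cyclohexyl ring there.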